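Chloro in Place of Nitro: Little Change Expected

The source may hold more compounds than are shown below. What is called first, only, known or untested is meant among the compounds shown, and "the series" means these compounds.

Of the compounds shown here, three have been tested in a functional assay on MCF7 cells (Homo sapiens) for antiproliferative activity, read by MTT assay, with a stated time of 24 h, tested at 0.0001 ug/mL; a higher number here means a weaker effect of the compound at the concentration tested, a lower number a stronger effect. Compound 1 `O=Cc1cn(-c2ccccc2)nc1-c1ccccc1O` gives 96%, compound 2 `O=Cc1cn(-c2ccccc2)nc1-c1ccc(Cl)cc1` gives 100%, and compound 3 `COc1cc(/C=C/C(=O)C(=Cc2cn(-c3ccccc3)nc2-c2ccc([N+](=O)[O-])cc2)C(=O)/C=C/c2ccc(O)c(OC)c2)ccc1O` gives 98%. Compound 3 sits between the other two, and each gap to it lies within the usual scatter, so all three are indistinguishable here and show almost no effect at this concentration. Compound 4 `COc1cc(/C=C/C(=O)C(=Cc2cn(-c3ccccc3)nc2-c2ccc(Cl)cc2)C(=O)/C=C/c2ccc(O)c(OC)c2)ccc1O` has not yet been measured. It differs from compound 3 in one place: chloro in place of nitro on an aromatic carbon. Since compound 1 and compound 2 also agree within scatter despite carrying different groups, the step from compound 3 to compound 4 in this assay is expected to be none beyond the scatter, no change at the digits printed from compound 3 to compound 4 (within the scatter). Compound 4 is therefore estimated at 98%, ranging from 90% to 104%.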

Compound 4, a percentage reported as activity, at one concentration (the size of the read-out at that concentration, not a potency): 95%
For compound 4 the middle estimate is 3 percentage points above the measured one; the range from low to high includes it.
By their numbers in this assay, from the lowest: compounds 4, 1, 3 and 2 (each within the scatter of the next).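

In this assay, for the compounds shown here, the change from 4-nitrophenyl to 4-chlorophenyl gives a number 3 percentage points lower from compound 3 to compound 4 (within the scatter) and is the first step that can be read at this position. Swapping these two groups leaves the read-out unchanged at this concentration, but compound 3 and compound 4 both show almost no effect, so this single step says little about the position. No evidence available here bears on this result.

On these data alone, whether an amine or a carboxylic acid at this position would read differently remains open. So does whether chloro and nitro would separate at a concentration where the compounds show a clear effect.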